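A few compounds are considered here, and "the series" means these few. Any claim that something is new, unique, unknown or untested is made for them only; others in the source may bear on it.

In a functional assay on PC-3 cells (Homo sapiens) for antiproliferative activity, read by MTT assay, with a stated time of 72 h (a higher number here means a weaker inhibitor, a lower number a stronger inhibitor), compound 1 `CCCCCCCCCNC[C@@H]1OC[C@H](N)[C@H]1O` gives 7650 nM. Two changes to it have been measured. Compound 2 `CCCCCCCCCCCCCCNC[C@@H]1OC[C@H](N)[C@H]1O` carries pentyl in place of hydrogen on a saturated chain carbon, nine bonds along the chain from an amine nitrogen and gives 1990 nM in this assay, a step of a 3.8-fold lower number from compound 1 to compound 2 (0.58 log units; beyond the scatter). Compound 3 `CCCCCCCCCNC[C@@H]1OC[C@H](N)[C@@H]1O` differs from compound 1 in another way: the two compounds have the same atoms and bonds and differ only in configuration as drawn: 1 of 3 stereo elements differ; a stereocentre at a saturated ring carbon is drawn R in compound 1 and S in compound 3. Compound 3 gives 2030 nM, and the step of a 3.8-fold lower number from compound 1 to compound 3 (0.58 log units; beyond the scatter) rests on (the fact that compounds 1 and 3 differ only in the configuration as drawn). The values of compound 2 and compound 3 lie within the scatter of each other, so nothing can be said about their order.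

Compound 4 `CCCCCCCCCCCCCCNC[C@@H]1OC[C@H](N)[C@@H]1O` has not yet been measured. It stands to compound 3 as compound 2 stands to compound 1: the difference is pentyl in place of hydrogen on a saturated chain carbon, nine bonds along the chain from an amine nitrogen, the same change as the one from compound 1 to compound 2, made on a core that differs from the core of compound 1 only as described above. This change occurs twice among the four compounds. Within the data shown here, the one measured example of it, from compound 1 to compound 2, gave a step of a 3.8-fold lower number from compound 1 to compound 2 (0.58 log units; beyond the scatter).

Among the measured compounds shown here, compound 4 is therefore expected to follow compound 3 with a step of a 3.4-fold lower number from compound 3 to compound 4 (0.53 log units; beyond the scatter), resting on the single measured step of a 3.8-fold lower number from compound 1 to compound 2 (0.58 log units; beyond the scatter) and on the value of compound 3, 2030 nM. On that basis compound 4 is estimated to give 600 nM in this assay, with the measurement expected to fall between 250 nM and 1500 nM.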

Compound 4, half-maximal inhibitory concentration: 1200 nM
Compound 4: middle estimate off by 2.0-fold (0.30 log units), on the low side; measured number inside the range.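

In this assay, the same pentyl change made on the core of compound 3 gives a 1.7-fold lower number from compound 3 to compound 4 (0.23 log units; within the scatter), so on this core the step does not stand clear of the scatter, as it did on the core of compound 1. This does not show that the change behaves differently on the two cores, nor does it prove that the two steps are equal in size, for the gap between them is not resolved: the same change on two cores in this assay, a 3.8-fold lower number (0.58 log units; beyond the scatter) from compound 1 to compound 2 and a 1.7-fold lower number (0.23 log units; within the scatter) from compound 3 to compound 4, 2.3-fold (0.36 log units) apart, within the scatter of two such steps. The step between the two longer-chain compounds, a 1.7-fold lower number from compound 2 to compound 4 (0.22 log units; within the scatter), also stays within the scatter, so these four compounds show that the change can be carried to the second core without a resolved difference in its step, but with one pair on each core they cannot fix the size of that step on either core.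

The compounds shown leave open how the values would run with a longer chain, or with a chain ending in an amine or a carboxylic acid, on either core. They also leave open what a different configuration at the other two stereocentres would give in combination with either chain.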